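This account rests on a few compounds, and the source may have more. Where it says the series, first, only, none or still open, it means among the compounds named here.

Measured so far:
compound 1 `O=C(O)c1c(F)cccc1-c1ccc2c(c1)OC[C@H](Cc1ccccc1)[C@H]2O`, 1000 nM
compound 2 `O=C(O)c1ccc(Cl)cc1-c1ccc2c(c1)OC[C@H](Cc1ccccc1)[C@H]2O`, 1300 nM
compound 3 `O=C(O)c1ccc(F)cc1-c1ccc2c(c1)OC[C@H](Cc1ccc(-c3ccccc3)cc1)[C@H]2O`, 700 nM; 5100 nM (2 entries)

All three were tested in a functional assay on blood with leukotriene B4 receptor (Homo sapiens) as the target; a lower number here means a stronger inhibitor, a higher number a weaker inhibitor. Compound 1 and compound 2 give numbers that lie within the usual scatter of each other, so the two cannot be told apart on these data. Compound 3 was tested more than once, and the several entries of compound 3 in this assay, 700 nM; 5100 nM (2 entries) shows how far two measurements of one compound can sit apart, a reminder to read any single number with care.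

The unmeasured compound is compound 4 `O=C(O)c1c(F)cc(F)cc1-c1ccc2c(c1)OC[C@H](Cc1ccccc1)[C@H]2O`. It differs from compound 1 in one place: fluoro in place of hydrogen on an aromatic carbon. The entering fluoro sits on the same aromatic ring as the fluoro already present in compound 1, meta to it and para to the carboxy group. Among the compounds with values here, no pair of measured compounds shows what this kind of change does, so there is nothing to anchor a direction. The step of a 1.1-fold lower number from compound 1 to compound 4 (0.05 log units; within the scatter) is expected to be small, not beyond the scatter. Compound 4 is expected to give about 900 nM in this assay, with a likely range from 350 nM to 2500 nM.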

Compound 4, half-maximal inhibitory concentration: 200 nM
The estimate for compound 4 lay 4.5-fold (0.65 log units) above the measured number; measured number outside the range, below it.
By their numbers in this assay, from the lowest: compound 4; then compounds 1 and 2 (each within the scatter of the next).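

In this assay, one fluoro added to the ring that carries the carboxy group, para to that carboxy group and meta to the fluoro already present, gives a 5.0-fold lower number from compound 1 to compound 4 (0.70 log units; beyond the scatter) and this step lies beyond the usual scatter. Within the data shown here, it is the first sign from a pair differing in one place that this position responds to a change, and that a single added atom can be enough to move the number. The reading rests on one step, though, and single numbers in this assay call for care: the several entries of compound 3 in this assay, 700 nM; 5100 nM (2 entries).

Still open, going by these compounds, is whether this response is particular to fluoro or would also appear with a methyl, methoxy or nitrile group at this position. Also open, on these data alone, is whether the step would hold with a different group on the shared core.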